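The source may report more compounds than this note shows. Statements on the series, on what has been measured and on what is new or still open speak of the compounds shown alone.

Two amides on one shared core have been tested in a toxicity assay on THP-1 cells (Homo sapiens) for inhibition; a higher number here means that more compound is tolerated, a lower number that less compound is tolerated: compound 1 (`COc1ccc(-c2cnc(NC(=O)c3cnc[nH]3)n2C)cc1`) and compound 2 (`COc1ccc(-c2cnc(NC(=O)C3CCCCC3)n2C)cc1`). Compound 1 gives > 100000 nM, which is a limit of the assay and not a number. Compound 2 gives > 100000 nM, which is also a limit. Compound 2 therefore has no number of its own, and the whole picture so far is the limit of > 100000 nM in this assay, at which 2 of the 2 values shown sit. For the measured compounds named here, the only measured step is a step that the two limits leave unreadable from compound 1 to compound 2, so it offers no size to carry forward.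

Compound 3 (`COc1ccc(-c2cnc(NC(=O)c3ccccc3Br)n2C)cc1`) has not yet been measured. It differs from compound 2 by one change on a carbonyl carbon, 2-bromophenyl in place of cyclohexyl on a carbonyl carbon. Going by the values given here, the expectation rests on compound 2, whose > 100000 nM is a limit, and no tested compound has yet given a number in this assay. No step beyond the scatter is therefore expected, and no direction can be given. The expected step is a number no higher from compound 2 to compound 3 (the limit leaves the size open). Compound 3 is estimated at 100000 nM, with an expected range from 40000 nM to 250000 nM, and it may well be reported only as a limit.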

Compound 3, half-maximal cytotoxic concentration: > 100000 nM
Compound 3 was reported as a limit (the forecaster's own chance of this, stated with the estimate: 75%); the middle value lies on the limit itself.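

Compound 3 also returns a limit and not a number, so neither its comparison with compound 2 nor its comparison with compound 1 yields a step that can be read. All three amides now stand at one value: the limit of > 100000 nM in this assay, at which 3 of the 3 values shown sit.

What the compounds shown leave open is how the three amides differ in this assay, and whether any amide on the shared core has a measurable cytotoxic concentration there.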